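Methylsulfanyl for Methylsulfonyl: What Efficacy to Expect

This account rests on a few compounds, and the source may have more. Where it says the series, first, only, none or still open, it means among the compounds named here.

In a functional assay for agonist activity at Alpha-1A adrenergic receptor (Homo sapiens) (on this read-out lower numbers stand for smaller maximal responses and higher numbers for larger maximal responses), compound 1 `CS(=O)(=O)c1cc(Cl)ccc1NCC1=NCCN1` gives 41%, while compound 2 `CS(=O)(=O)c1cc(F)ccc1NCC1=NCCN1` gives 61%, the higher of the two numbers, reached through a number 20 percentage points higher from compound 1 to compound 2 (beyond the scatter). Compound 3 `CSc1cc(F)ccc1NCC1=NCCN1` differs from compound 2 in one place: methylsulfanyl in place of methylsulfonyl on an aromatic carbon. For the measured compounds named here, no measured step bears on this change; the single known step concerns fluoro in place of chloro and offers no guide here. One therefore expects no step beyond the scatter in this assay, with wide uncertainty. For compound 3 the expected value is 61%, between 35% and 85%, which means an estimated step of no change at the digits printed from compound 2 to compound 3 (within the scatter).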

Compound 3, largest response reached (reported as maximum), in percent of the reference or control that the assay uses: 93%
Compound 3: the middle estimate sits 32 percentage points below what was measured, outside the stated range (above it).
By their numbers in this assay, from the lowest: compound 1; then compound 2; then compound 3.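

For the compounds shown here, the sulfur group on this aromatic carbon proves to be a strong handle on maximal response in this assay: the change from methylsulfonyl to methylsulfanyl gives a number 32 percentage points higher from compound 2 to compound 3 (beyond the scatter) and is a large step, whereas the earlier compounds showed only a modest step from a change of halogen. On these data alone, whether the same change carries over with chloro in place of fluoro stays open, as does what a methoxy group or a longer chain would give at this position. Nothing at hand accounts for the size of this step.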